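The compounds below may be only part of what the source reports. "The series", "measured", "known", "first", "only" and "open" are said of these compounds alone.

Series notes. In a functional assay for activation of Alpha-1D adrenergic receptor (Homo sapiens) (a higher number here means that more compound is needed for the effect, a lower number that less compound is needed), compound 1 `Cc1ncc(-c2ccccc2NCC2=NCCN2)o1` returns only a limit of the assay, < 5020 nM. Compound 2 `Cc1nc(-c2ccccc2NCC2=NCCN2)cs1` likewise returns only a limit, < 5020 nM. Compound 3 `Cc1cc(-c2ccccc2NCC2=NCCN2)on1` also returns only a limit, < 100000 nM. Compound 3 thus sits at the limit of < 100000 nM in this assay, at which 1 of the 3 values shown sits, whereas the other two sit at the limit of < 5020 nM in this assay, at which 2 of the 3 values shown sit; none of the three figures is a number. The steps a step that the two limits leave unreadable from compound 1 to compound 2, a step that the two limits leave unreadable from compound 1 to compound 3 and a step that the two limits leave unreadable from compound 2 to compound 3 cannot be read for size or direction.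

The next compound, compound 4 `Cc1ccsc1-c1ccccc1NCC1=NCCN1`, differs from compound 3 by 3-methylthiophen-2-yl in place of 3-methyl-1,2-oxazol-5-yl on an aromatic carbon. Going by the values given here, no measured step bears on this exchange in a readable way: the three known steps are all bounded by limits, so no size of step and no direction can be derived from them. The expectation for compound 4 is therefore anchored on the side of the tighter limit, which compound 1 shows as < 5020 nM. Compound 2 gives the same kind of anchor with < 5020 nM. On that basis compound 4 is expected to give 1000 nM in this assay, with a range from 100 nM to 10000 nM. The step from compound 3 to compound 4 is accordingly estimated as a step that the limit leaves unreadable from compound 3 to compound 4, a figure resting on a limit rather than a measured number for compound 3.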

Compound 4, half-maximal effective concentration: 49 nM
Compound 4: the middle estimate sits 20-fold (1.31 log units) above what was measured; measured number below the stated range.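

Compound 4 gives 49 nM. Compound 1, compound 2 and compound 3 return only limits of the assay, so the steps from each of them to compound 4 cannot be read for size or direction. The compounds shown leave open how far 3-methylthiophen-2-yl differs in number from the three other groups in this position.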